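A few compounds are considered here, and "the series" means these few. Any claim that something is new, unique, unknown or untested is made for them only; others in the source may bear on it.

Compound 3 `N=C1S/C(=C\c2ccc(OCc3ccccc3)cc2)C(=O)N1c1ccccc1` gives 37.9% in an ADME assay on RAW264.7 cells (Mus musculus) for cytotoxicity, read by MTT assay, with a stated time of 48 h, tested at 50 uM (a lower number here means less inhibition, a higher number more inhibition at the concentration tested (going by the name of the read-out)), the second highest of three numbers: compound 1 `N=C1S/C(=C\c2ccc(OCc3ccccc3)cc2)C(=O)N1c1ccc(Cl)cc1` gives 16.4%, and compound 2 `Cc1c(Cl)cccc1N1C(=N)S/C(=C\c2ccc(OCc3ccccc3)cc2)C1=O` gives 59.7%. The measured steps show that an aryl substituent on this ring nitrogen matters: a number 21.8 percentage points lower from compound 2 to compound 3 (beyond the scatter), a number 43.3 percentage points higher from compound 1 to compound 2 (beyond the scatter), and a number 21.5 percentage points higher from compound 1 to compound 3 (beyond the scatter). Compound 4 `Cc1ccc(N2C(=N)S/C(=C\c3ccc(OCc4ccccc4)cc3)C2=O)c(C)c1` is not yet measured; it differs from compound 3 in that (2,4-dimethylphenyl in place of phenyl on an amide-type nitrogen in a ring). The step in which phenyl replaced 3-chloro-2-methylphenyl was modest and downward, so the reverse direction, adding methyl groups to the phenyl, is expected to raise inhibition, though the change here is not identical. For compound 4 the expected step is a number 17.1 percentage points higher from compound 3 to compound 4 (beyond the scatter), and the estimate is 55%, within a range from 35% to 75%.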

Compound 4, a percentage reported as inhibition, at one concentration (the size of the read-out at that concentration, not a potency): 36.8%
Compound 4: the middle estimate sits 18.2 percentage points above what was measured, and the stated range covers the measured number.
By their numbers in this assay, from the lowest: compound 1; then compounds 4 and 3 (each within the scatter of the next); then compound 2.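

In this assay, with a number 1.1 percentage points lower from compound 3 to compound 4 (within the scatter), the 2,4-dimethylphenyl group on this ring nitrogen does not separate from plain phenyl, so methyl groups alone do not raise the number here. It falls short of the 3-chloro-2-methylphenyl group, with a number 22.9 percentage points lower from compound 2 to compound 4 (beyond the scatter), yet, with a number 20.4 percentage points higher from compound 1 to compound 4 (beyond the scatter), it stands clear of the 4-chlorophenyl group. Nothing available explains these differences. Open, from the compounds shown here alone, is whether an amine or a carboxylic acid on this phenyl, or a longer alkyl chain in its place, would shift the number.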